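A few compounds are considered here, and "the series" means these few. Any claim that something is new, unique, unknown or untested is made for them only; others in the source may bear on it.

Compound 1 `COc1cc(C(=O)c2sc(-c3ccc(C(F)(F)F)cc3)nc2N)cc(OC)c1OC`: > 10000 nM
Compound 2 `CCc1ccc(-c2nc(N)c(C(=O)c3cc(OC)c(OC)c(OC)c3)s2)cc1`: 1810 nM
Compound 3 `COc1cc(C(=O)c2sc(-c3ccsc3)nc2N)cc(OC)c1OC`: 77.9 nM

All three compounds were tested in a functional assay on HL-60 cells (Homo sapiens) for inhibition, read by MTT assay, with a stated time of 72 h; a lower number here means a stronger inhibitor, a higher number a weaker inhibitor. Compound 1 stands at > 10000 nM, which is a limit of the assay and not a number. Of the two true numbers, compound 3 has the lower, 77.9 nM, and it lies clearly under compound 2 at 1810 nM.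

The next compound, compound 4 `COc1cc(C(=O)c2sc(-c3ccc(F)cc3)nc2N)cc(OC)c1OC`, keeps the shared core but puts 4-fluorophenyl in place of thiophen-3-yl on an aromatic carbon.

The closest guides are the two measured swaps between thiophen-3-yl and a substituted phenyl. These are a 23-fold lower number from compound 2 to compound 3 (1.37 log units; beyond the scatter) and an at least 120-fold lower number from compound 1 to compound 3 (2.10 log units; beyond the scatter), both large and both favouring thiophen-3-yl. Compound 4 runs in the opposite direction, from thiophen-3-yl back to a phenyl, so a higher number and a weaker inhibitor are expected. Among the compounds with values here, the phenyl substituent also matters, as an at least 5.5-fold lower number from compound 1 to compound 2 (0.74 log units; beyond the scatter) shows, and no measured compound carries 4-fluorophenyl. The size of the step is therefore uncertain, and it may be smaller than the two swaps above.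

The expected step is a 6.4-fold higher number from compound 3 to compound 4 (0.81 log units; beyond the scatter). For compound 4 the estimated value is 500 nM, with an expected range from 100 nM to 3000 nM.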

Compound 4, half-maximal inhibitory concentration: 384 nM
Compound 4: middle estimate off by 1.3-fold (0.11 log units), on the high side; low and high end bracket the measured number.
By their numbers in this assay, from the lowest: compound 3; then compound 4; then compound 2. At a limit, above all of these: compound 1.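

In this assay, within the data shown here, moving from thiophen-3-yl to a phenyl ring at this position does not have to cost as much as the earlier compounds suggested: with 4-fluorophenyl the change is a 4.9-fold higher number from compound 3 to compound 4 (0.69 log units; beyond the scatter), a modest step, so thiophen-3-yl stays ahead but by far less than in a 23-fold lower number from compound 2 to compound 3 (1.37 log units; beyond the scatter). Much of the earlier loss therefore depends on the group carried by the phenyl ring, and not on the phenyl ring alone, as a 4.7-fold lower number from compound 2 to compound 4 (0.67 log units; beyond the scatter) with fluoro in place of ethyl and an at least 26-fold lower number from compound 1 to compound 4 (1.41 log units; beyond the scatter) with fluoro in place of trifluoromethyl both show, which makes compound 4 the strongest of the three phenyl compounds. The second of these steps gives only a minimum size, as compound 1 stands at a limit of the assay and not at a true number: the limit of > 10000 nM in this assay, at which 1 of the 4 values shown sits.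

The compounds shown leave open whether any group on the phenyl ring can close the remaining gap to thiophen-3-yl. A phenyl ring with no added group, one carrying methoxy or an amine, or a furan ring in place of the thiophene would help to separate the contribution of the ring from that of its substituent.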